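Methoxy to methylsulfanyl on the aryl ring of compound 2

This account rests on a few compounds, and the source may have more. Where it says the series, first, only, none or still open, it means among the compounds named here.

The series is measured for inhibition in a functional assay on the whole organism (Pleural cavity) for inhibition, with Rattus norvegicus as the target, at a dose of 25 mg/kg; a lower number here means less inhibition, a higher number more inhibition at the dose given (going by the name of the read-out). Compound 2 `COc1ccc(N2C(=O)C(C)(C)c3cccnc32)cc1` gives 63% there, the highest of the three numbers; compound 1 `CC1(C)C(=O)N(c2ccc(S(C)(=O)=O)cc2)c2ncccc21` gives 42% and compound 3 `CSC1(C)C(=O)N(c2ccccc2)c2ncccc21` gives 34%, both steps to compound 2 lying beyond the scatter. Going by the values given here, the one step between compounds that differ in a single place runs a number 21 percentage points higher from compound 1 to compound 2 (beyond the scatter), methoxy in place of methylsulfonyl on an aromatic carbon. Compound 4 `CSc1ccc(N2C(=O)C(C)(C)c3cccnc32)cc1` differs from compound 2 by methylsulfanyl in place of methoxy on an aromatic carbon, the change sitting on an aromatic carbon of a six-membered aromatic ring of carbon only, para to a large group. Among the compounds with values here, no measured pair shows this exact exchange. Within the data shown here, the only step at the same place is the one from compound 1 to compound 2, in which a sulfur-bearing group gave way to methoxy and the read-out rose; the new group again carries sulfur but is not methylsulfonyl, so that step is a loose guide at best. Compound 3 carries methylsulfanyl elsewhere, on the shared core rather than on the aryl ring, and its value is not a step from compound 2. The step to compound 4 is expected to be small and downward, a number 8 percentage points lower from compound 2 to compound 4 (within the scatter), possibly within the scatter. Compound 4 is estimated to give 55% in this assay, within a range of 35% to 75%.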

Compound 4, a percentage reported as inhibition, in the whole organism at one dose (the size of the read-out at that dose, not a potency): 29%
For compound 4 the middle estimate is 26 percentage points above the measured one; measured number outside the range, below it.
By their numbers in this assay, from the lowest: compounds 4, 3 and 1 (each within the scatter of the next, the first and the last beyond it); then compound 2.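

At this aromatic carbon, para to a large group, methylsulfanyl in place of methoxy gives a number 34 percentage points lower from compound 2 to compound 4 (beyond the scatter) in this assay, so the exchange of oxygen for sulfur in this small group matters a great deal at the dose given. The two groups match in every count computed for them, so those counts do not follow the read-out here. The two sulfur-bearing groups also part from each other, with a number 13 percentage points lower from compound 1 to compound 4 (beyond the scatter) on going from methylsulfonyl to methylsulfanyl, and of the three groups seen at this place, methoxy gives the highest number, beyond the scatter of both others. No measurement shown here accounts for the size of these steps.

As far as these compounds go, it remains open whether an ethoxy group, a chlorine atom or an amine at this place would reach the number of compound 2, or whether methoxy stands alone among such groups. Also open, from the compounds shown here alone, is how these groups would rank at other doses, since the whole series is read at a single dose.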